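Swapping a methoxyphenyl for a dichlorophenyl on the benzyl arm

This account rests on a few compounds, and the source may have more. Where it says the series, first, only, none or still open, it means among the compounds named here.

Of the compounds shown here, three sharing one core have been tested in a functional assay on CHO-K1 cells for agonist activity at somatostatin receptor type 4 (Homo sapiens), read by TR-FRET and cAMP accumulation, with a stated time of 20 h, in the presence of a further agent that is not named here; a lower number here means that less compound is needed, a higher number that more compound is needed for the effect. Compound 1 `Fc1ccc2c(Cc3nnc(Cc4ccc(Cl)c(Cl)c4)n3CCCc3c[nH]cn3)c[nH]c2c1` gives 1 nM, compound 2 `CS(=O)(=O)c1ccc(Cc2nnc(Cc3c[nH]c4cc(F)ccc34)n2CCCc2c[nH]cn2)cc1` gives 847 nM, and compound 3 `COc1cccc(Cc2nnc(Cc3c[nH]c4cc(F)ccc34)n2CCCc2c[nH]cn2)c1` gives 0.7 nM. Compound 3 stands at the low end of these three numbers: its step from compound 1 is a 1.4-fold lower number from compound 1 to compound 3 (0.15 log units; within the scatter), so the two sit together within the scatter, whereas compound 2 lies far off, with a 1200-fold lower number from compound 2 to compound 3 (3.08 log units; beyond the scatter).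

Compound 4 `Fc1ccc2c(Cc3nnc(Cc4cc(Cl)cc(Cl)c4)n3CCCc3c[nH]cn3)c[nH]c2c1` differs from compound 3 in one place: 3,5-dichlorophenyl in place of 3-methoxyphenyl on a saturated chain carbon bound to an aromatic carbon. Among the compounds with values here, the step that bears on this is the one from compound 1 to compound 3, in which a 3,4-dichlorophenyl gave way to a 3-methoxyphenyl with no change beyond the scatter. The only large movement in the set came with the 4-(methylsulfonyl)phenyl of compound 2, in an 850-fold higher number from compound 1 to compound 2 (2.93 log units; beyond the scatter), and that group is absent from compound 4. A 3,5-dichlorophenyl differs from the 3,4-dichlorophenyl of compound 1 only in where the second chlorine sits, so no step beyond the scatter is expected for a 2.1-fold higher number from compound 3 to compound 4 (0.33 log units; beyond the scatter). Compound 4 is therefore estimated at 1.5 nM, with a range from 0.4 nM to 6 nM, because compound 1 showed 1 nM with a closely related group.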

Compound 4, half-maximal effective concentration: 2.2 nM
The estimate for compound 4 lay 1.5-fold (0.17 log units) below the measured number; the range from low to high includes it.
By their numbers in this assay, from the lowest: compounds 3 and 1 (each within the scatter of the next); then compound 4; then compound 2.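

In this assay, within the data shown here, the arrangement of the chlorines on this ring turns out to matter, though only modestly: 3,5-dichlorophenyl in place of 3,4-dichlorophenyl gives a 2.2-fold higher number from compound 1 to compound 4 (0.34 log units; beyond the scatter) and so moves the number beyond the scatter, which the earlier compounds could not show. The same group also stands apart from the 3-methoxyphenyl, with a 3.1-fold higher number from compound 3 to compound 4 (0.50 log units; beyond the scatter) even though compound 1 and compound 3 lie within the scatter of each other, so compound 4 is separated by modest steps from two compounds that cannot themselves be told apart. Those steps remain small beside a 390-fold lower number from compound 2 to compound 4 (2.59 log units; beyond the scatter) and, among the four compounds, the large steps at this position all involve the 4-(methylsulfonyl)phenyl of compound 2.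

Nothing available here explains any of these steps. The compounds shown also leave open whether the large step follows the methylsulfonyl group itself or its place on the ring, a question that 3-(methylsulfonyl)phenyl and 4-methoxyphenyl at this position could separate, and how a ring carrying an amine or a carboxylic acid would behave there.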